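Dropping a Methyl from the Core of Compound 1

This account rests on a few compounds, and the source may have more. Where it says the series, first, only, none or still open, it means among the compounds named here.

Of the compounds shown here, three have been measured in an assay for inhibition of Amine oxidase [flavin-containing] B (Homo sapiens), read by fluorescence, using microsomes, with a stated time of 30 min; a lower number here means a stronger inhibitor, a higher number a weaker inhibitor. Compound 1 `Cc1c(C)c2ccc(OCC3CCN(Cc4ccc(CO)cc4)CC3)cc2oc1=O` gives 29 nM, the lowest number of the three. Compound 2 `Cc1c(C)c2ccc(OCC3CCN(Cc4cccc(CO)c4)CC3)cc2oc1=O` differs from it only in the benzyl arm, (4-(hydroxymethyl)phenyl in place of 3-(hydroxymethyl)phenyl on a saturated chain carbon bound to an amine nitrogen in a ring), and in this assay compound 2 gives 76 nM; the step is a 2.6-fold higher number from compound 1 to compound 2 (0.42 log units; beyond the scatter). Compound 3 `Cc1cc(=O)oc2cc(OCC3CCN(Cc4cccc(CO)c4)CC3)ccc12` carries one methyl less than compound 2, (hydrogen in place of methyl on an aromatic carbon), and in this assay compound 3 gives 480 nM, so that a 6.3-fold higher number from compound 2 to compound 3 (0.80 log units; beyond the scatter).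

Compound 4 `Cc1cc2ccc(OCC3CCN(Cc4ccc(CO)cc4)CC3)cc2oc1=O` is not yet measured. It stands to compound 1 as compound 3 stands to compound 2: hydrogen in place of methyl on an aromatic carbon. This is the same kind of change, not the same one, since the place differs: in compound 2 the methyl that leaves sits ortho to a group of 1 heavy atom, two atoms from the ring oxygen and para to a fused ring, whereas in compound 1 it sits ortho to a fused ring, meta to a group of 1 heavy atom and opposite the ring oxygen. Resting on the single measured case of this kind, a 6.3-fold higher number from compound 2 to compound 3 (0.80 log units; beyond the scatter), a step of similar size is expected, a 5.2-fold higher number from compound 1 to compound 4 (0.71 log units; beyond the scatter). Compound 4 is therefore estimated at 150 nM in this assay, expected to lie between 55 nM and 400 nM.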

Compound 4, half-maximal inhibitory concentration: 3100 nM
For compound 4 the middle estimate is 21-fold (1.32 log units) below the measured one, and the stated range ends below it.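

In this assay the loss of the methyl opposite the ring oxygen is a large step, a 110-fold higher number from compound 1 to compound 4 (2.03 log units; beyond the scatter). Both measured losses of a methyl raise the number, but the size of the step does not carry over from one core to the other: the same change on two cores in this assay, a 6.3-fold higher number (0.80 log units; beyond the scatter) from compound 2 to compound 3 and a 110-fold higher number (2.03 log units; beyond the scatter) from compound 1 to compound 4, 17-fold (1.23 log units) apart, beyond the scatter of two such steps This shows that the step measured on compound 2 was a poor guide to the step on compound 1; it does not show what sets the two steps apart, as they differ both in which methyl leaves and in the arm, 3-(hydroxymethyl)phenyl in one and 4-(hydroxymethyl)phenyl in the other, and these two differences cannot be separated here.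

The compounds shown leave open how each methyl behaves on the other arm, which is what would tell the place of the methyl from the effect of the arm. They also leave open whether an ethyl group or a chlorine on that aromatic carbon would keep the number as low as the methyl of compound 1 does.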